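This account rests on a few compounds, and the source may have more. Where it says the series, first, only, none or still open, it means among the compounds named here.

Compounds measured so far:
- compound 1, `O=C(O)COCc1nc(Nc2ccc(C(F)(F)F)cc2)c2ccc(-c3ncccc3C(F)(F)F)cc2n1`: 81 nM
- compound 2, `O=C(O)CCc1nc(Nc2ccc(C(F)(F)F)cc2)c2ccc(-c3ncccc3C(F)(F)F)cc2n1`: 1630 nM

Among the compounds with values here, in a functional assay for antagonist activity at transient receptor potential cation channel subfamily V member 1 (Homo sapiens) (on this read-out lower numbers stand for stronger inhibition and higher numbers for weaker inhibition), compound 2 stands at the higher of the two numbers, the weaker inhibitor of the pair; its nearest neighbour is compound 1, and the single measured step, a 20-fold higher number from compound 1 to compound 2 (1.30 log units; beyond the scatter), lies well beyond the scatter. Compound 3, `CNCc1nc(Nc2ccc(C(F)(F)F)cc2)c2ccc(-c3ncccc3C(F)(F)F)cc2n1`, is not yet measured. It differs from compound 2 as methylamino in place of carboxymethyl on a saturated chain carbon bound to an aromatic carbon. Within the data shown here, no measured step bears directly on this exchange: the only step in hand concerns the link between the chain and the acid, not the acid itself, so it shows only that changes at this saturated chain carbon can move the number by a large amount in either direction. The direction for compound 3 is therefore open, and a wide range is appropriate. Compound 3 is estimated at 600 nM in this assay, within 100 nM to 4000 nM, which corresponds to an expected step of a 2.7-fold lower number from compound 2 to compound 3 (0.43 log units; beyond the scatter).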

Compound 3, half-maximal inhibitory concentration: 26 nM
Compound 3: the middle estimate sits 23-fold (1.36 log units) above what was measured; the measured number lies below the stated range.
By their numbers in this assay, from the lowest: compound 3; then compound 1; then compound 2.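

In this assay, placing methylamino in place of carboxymethyl on a saturated chain carbon bound to an aromatic carbon gives a 63-fold lower number from compound 2 to compound 3 (1.80 log units; beyond the scatter) and shows that a carboxylic acid is not needed at this position for strong inhibition. The same group also goes beyond the carboxymethoxy chain, with a 3.1-fold lower number from compound 1 to compound 3 (0.49 log units; beyond the scatter) as a modest but real gain, which makes compound 3 the strongest inhibitor of the three, although its chain is the shortest by heavy-atom count of the exchanged group. Nothing at hand accounts for these steps.

The compounds shown leave open whether the gain belongs to the nitrogen itself or to this particular amine. A dimethylamino group, a primary amine or a longer chain carrying the amine at this carbon would separate these readings.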